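Swapping one aromatic group on compound 3

This account rests on a few compounds, and the source may have more. Where it says the series, first, only, none or still open, it means among the compounds named here.

Values in an ADME assay on Vero cells (Chlorocebus sabaeus) for cytotoxicity, read by MTT assay, with a stated time of 72 h; on this read-out lower numbers stand for higher toxicity in this test and higher numbers for lower toxicity in this test:
Compound 1 `O=c1nc(N2CCN(NCC3CCCCC3)CC2)sc2c([N+](=O)[O-])cc(C(F)(F)F)cc12`: 29.3 ug/mL
Compound 2 `CC(C)CN(CC(C)C)N1CCN(c2nc(=O)c3cc(C(F)(F)F)cc([N+](=O)[O-])c3s2)CC1`: > 64 ug/mL (a limit)
Compound 3 `O=c1nc(N2CCN(NCc3ccc(OC(F)(F)F)cc3)CC2)sc2c([N+](=O)[O-])cc(C(F)(F)F)cc12`: > 64 ug/mL (a limit)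

Compound 3 gives > 64 ug/mL, a limit and not a number, and so sits at the limit of > 64 ug/mL in this assay, at which 2 of the 3 values shown sit. Compound 4 `O=c1nc(N2CCN(NCc3ccc(Br)cc3)CC2)sc2c([N+](=O)[O-])cc(C(F)(F)F)cc12`, still unmeasured, carries bromo in place of trifluoromethoxy on an aromatic carbon, para to a large group: bromo in place of trifluoromethoxy on an aromatic carbon. The closest measured changes are an at least 2.1-fold higher number from compound 1 to compound 3 (0.33 log units; beyond the scatter) and an at least 2.1-fold higher number from compound 1 to compound 2 (0.33 log units; beyond the scatter). Neither of them touches this aromatic group, though compound 4 keeps the phenyl ring that an at least 2.1-fold higher number from compound 1 to compound 3 (0.33 log units; beyond the scatter) brought in. No shift beyond the scatter is therefore expected. The expected change is an estimated a number no higher from compound 3 to compound 4 (the limit leaves the size open). For compound 4 the estimate is 64 ug/mL, with an expected range of 28 ug/mL to 128 ug/mL.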

Compound 4, half-maximal cytotoxic concentration: > 64 ug/mL
Compound 4 ended at the assay's limit; the forecaster's own chance of this, stated with the estimate: 60%; the middle value sits exactly at the limit.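

On this aromatic carbon, bromo can take the place of trifluoromethoxy and this assay still returns no readable number. The 4-bromophenyl group also gives an at least 2.1-fold higher number from compound 1 to compound 4 (0.33 log units; beyond the scatter), so the gain seen with the phenyl ring does not depend on trifluoromethoxy alone. The steps to compound 4 from compound 2 and from compound 3 cannot be read, because each joins two limits: the limit of > 64 ug/mL in this assay, at which 3 of the 4 values shown sit.

As far as these compounds go, whether an amine or a carboxylic acid on this same aromatic carbon would bring a readable number in this assay stays open. So does the effect of a bare phenyl ring with nothing on that carbon.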